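Nitro in Place of Bromo: Expecting Compound 3

The source may hold more compounds than are shown below. What is called first, only, known or untested is meant among the compounds shown, and "the series" means these compounds.

Compound 1 `O=C(/C=C/c1ccc(OCc2cn(Cc3ccccc3F)nn2)cc1)c1ccc(Br)cc1`: 38%
Compound 2 `O=C(/C=C/c1ccc(OCc2cn(Cc3ccc(F)cc3)nn2)cc1)c1ccc(Br)cc1`: 37%

In a functional assay on MCF7 cells (Homo sapiens) for inhibition, read by MTT assay, with a stated time of 48 h, tested at 10 uM (on this read-out higher numbers stand for more inhibition of growth at the one concentration tested and lower numbers for less inhibition of growth), compound 1 gives 38%, and compound 2 gives 37%. Going by the values given here, the only measured step, a number 1 percentage points lower from compound 1 to compound 2 (within the scatter), lies within the scatter. Compound 2 stands at the lowest of the two numbers, with compound 1 as its nearest neighbour by a margin within the scatter, so no order can be read between the two.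

Compound 3 `O=C(/C=C/c1ccc(OCc2cn(Cc3ccc(F)cc3)nn2)cc1)c1ccc([N+](=O)[O-])cc1` differs from compound 2 by nitro in place of bromo on an aromatic carbon. Among the compounds with values here, no measured step bears on this change: the single step available concerns a different part of the structure and was itself within the scatter. The two numbers therefore give no ground for expecting a step beyond the scatter in either direction. Compound 3 is accordingly expected to give about 37%, within a range from 18% to 56%, which means an estimated step of no change at the digits printed from compound 2 to compound 3 (within the scatter).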

Compound 3, percent growth inhibition at one concentration: 38%
Estimate against measurement, compound 3: 1 percentage points below, within the range that was stated.
By their numbers in this assay, from the lowest: compounds 2, 1 and 3 (each within the scatter of the next).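

In this assay the exchange of 4-bromophenyl for 4-nitrophenyl on the carbonyl gives a number 1 percentage points higher from compound 2 to compound 3 (within the scatter). Going by these compounds alone, this is the first measured step at this position, which the earlier pair left the same, and it shows that one heavy atom can give way to three, with two hydrogen-bond acceptors entering, while the read-out stays within the scatter. On this read-out the two groups cannot be told apart, and no measurement at hand offers an account of why they read alike.

As far as these compounds go, whether an amine or a carboxylic acid at this position, in place of bromo or nitro, would move the number beyond the scatter remains open. Also open, from the compounds shown here alone, is whether 4-nitrophenyl would read alike with the 2-fluorophenyl of compound 1 in place of the 4-fluorophenyl of compound 3.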